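Azaheteroaryl thioether variants on the aminopyridine dinitrile core

The source may report more compounds than this note shows. Statements on the series, on what has been measured and on what is new or still open speak of the compounds shown alone.

Measured compounds:
compound 1 `N#Cc1c(N)nc(SCc2cccc(C(N)=O)c2)c(C#N)c1-c1ccc(OCC2CC2)cc1` — 12.7 nM
compound 2 `N#Cc1c(N)nc(SCc2ncn[nH]2)c(C#N)c1-c1ccc(OCC2CC2)cc1` — 51 nM
compound 3 `CCOc1ccc(-c2c(C#N)c(N)nc(SCc3ncc[nH]3)c2C#N)cc1` — 11.7 nM

All three were run in a functional assay on CHO cells for agonist activity at adenosine receptor A2b (Homo sapiens), read by AlphaScreen and cAMP accumulation; on this read-out lower numbers stand for an effect already at smaller amounts and higher numbers for an effect only at larger amounts of compound. Compound 1 stands second highest of the three numbers; compound 3 is nearest, within the scatter, while compound 2 lies furthest, beyond the scatter. Going by the values given here, the single one-place step in the set, a 4.0-fold higher number from compound 1 to compound 2 (0.60 log units; beyond the scatter), replaces 3-carbamoylphenyl with 1H-1,2,4-triazol-5-yl on the saturated chain carbon bound to the sulfur and gives a modest loss.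

Compound 4 `N#Cc1c(N)nc(SCc2ncc[nH]2)c(C#N)c1-c1ccc(OCC2CC2)cc1` is not yet measured. Relative to compound 1 it carries 1H-imidazol-2-yl in place of 3-carbamoylphenyl on a saturated chain carbon bound to a sulfur. The step that bears on this is a 4.0-fold higher number from compound 1 to compound 2 (0.60 log units; beyond the scatter), since it also exchanges the same 3-carbamoylphenyl for a five-membered azole on the same carbon; that step was modest and beyond the scatter. Compound 3, which gives 11.7 nM, sits within the scatter of compound 1 and suggests the core tolerates an azole here without a large penalty. A small to modest rise in the number is therefore expected for compound 4, around a 2.0-fold higher number from compound 1 to compound 4 (0.29 log units; within the scatter), though a result within the scatter of compound 1 cannot be excluded. The estimate for compound 4 is 25 nM, with a range from 8 nM to 80 nM.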

Compound 4, half-maximal effective concentration: 9.5 nM
For compound 4 the middle estimate is 2.6-fold (0.42 log units) above the measured one, within the range that was stated.
By their numbers in this assay, from the lowest: compounds 4, 3 and 1 (each within the scatter of the next); then compound 2.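

In this assay, 1H-imidazol-2-yl in place of 3-carbamoylphenyl on the saturated chain carbon bound to a sulfur gives a 1.3-fold lower number from compound 1 to compound 4 (0.13 log units; within the scatter), so on the cyclopropyl-bearing side of the series this carbon accepts the five-membered ring of 5 heavy atoms as readily as the six-membered aromatic group of 9 heavy atoms. The identity of the azole does count, since 1H-imidazol-2-yl in place of 1H-1,2,4-triazol-5-yl at the same carbon gives a 5.4-fold lower number from compound 2 to compound 4 (0.73 log units; beyond the scatter), which places the earlier loss with the triazole alone and not with azoles at this carbon in general, as far as these two azoles go. With 1H-imidazol-2-yl held constant, cyclopropyl in place of methyl on the saturated chain carbon bound to an oxygen on an aromatic ring gives a 1.2-fold lower number from compound 3 to compound 4 (0.09 log units; within the scatter), so that change cannot be read as having any effect here.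

Nothing available offers a reason for the gap between the two azoles. Still open, as far as these compounds go, is how a pyridyl ring, a carboxylic acid in place of the carbamoyl group, or a longer chain between the sulfur and the 1H-imidazol-2-yl would read on this scale.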